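A few compounds are considered here, and "the series" means these few. Any claim that something is new, unique, unknown or untested is made for them only; others in the source may bear on it.

Measured in a functional assay on cells for antagonist activity at C-X-C chemokine receptor type 4 (Homo sapiens), read by fluorescence and calcium flux, with stated times of 25 min and 90 s; on this read-out higher numbers stand for weaker inhibition and lower numbers for stronger inhibition:
compound 1 `FC1(F)CCC(NCc2ccc(CN(C[C@H]3Cc4ccccc4CN3)[C@H]3CCCc4cccnc43)cc2)CC1` gives 143 nM;
compound 2 `CC1(C)CCC(NCc2ccc(CN(C[C@H]3Cc4ccccc4CN3)[C@H]3CCCc4cccnc43)cc2)CC1` gives 661 nM.

Within the data shown here, compound 2 stands with the higher of the two numbers; its nearest companion is compound 1, and the single step that connects them, a 4.6-fold higher number from compound 1 to compound 2 (0.66 log units; beyond the scatter), lies beyond the scatter. The unmeasured compound 3 `c1ccc2c(c1)CN[C@@H](CN(Cc1ccc(CNCc3ccncc3)cc1)[C@H]1CCCc3cccnc31)C2` differs from compound 2 in one place: (pyridin-4-yl)methyl in place of 4,4-dimethylcyclohexyl on an amine nitrogen. Among the measured compounds shown here, no measured step bears directly on this exchange. For the measured compounds named here, the one step in hand concerns a change within the same saturated ring, not the replacement of that ring by an aromatic one, so it cannot tell the direction here; it shows only that a change at this amine nitrogen can move the number beyond the scatter. On that basis a step of moderate size is expected for compound 3 in this assay, without a firm direction, and the estimated step of a 1.9-fold lower number from compound 2 to compound 3 (0.28 log units; within the scatter) is placed slightly toward a lower number. Compound 3 is therefore expected to give about 350 nM, within a range from 100 nM to 1200 nM.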

Compound 3, half-maximal inhibitory concentration: 134 nM
Compound 3: the middle estimate sits 2.6-fold (0.42 log units) above what was measured, within the range that was stated.
By their numbers in this assay, from the lowest: compounds 3 and 1 (each within the scatter of the next); then compound 2.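

In this assay, among these compounds, putting (pyridin-4-yl)methyl in place of 4,4-dimethylcyclohexyl on the amine nitrogen gives a 4.9-fold lower number from compound 2 to compound 3 (0.69 log units; beyond the scatter) and so shows that this position also tolerates a group with an aromatic ring holding a hetero atom, where the earlier compounds carried only saturated carbon rings. Set against 4,4-difluorocyclohexyl, the same group gives a 1.1-fold lower number from compound 1 to compound 3 (0.03 log units; within the scatter) and so places two quite different groups within the scatter of each other, leaving compound 2, with its 4,4-dimethylcyclohexyl, as the one apart among these three. Nothing at hand gives a reason for either result.

The compounds shown leave open whether the ring nitrogen of the pyridine counts for anything here, as a plain benzyl group on the same amine nitrogen would show, and whether its place in the ring matters, as (pyridin-2-yl)methyl or (pyridin-3-yl)methyl would show. They also leave open what the methylene link contributes, which a pyridin-4-yl group set directly on the nitrogen or a cyclohexylmethyl group could test.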